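The compounds below may be only part of what the source reports. "The series", "measured", "known", "first", "only" and "open" are said of these compounds alone.

Compound 1 `N#CC1=C(N)Oc2c(c3nc4ccccc4nc3c3ccccc23)C12C(=O)N(Cc1cnnn1-c1ccc(F)cc1)c1ccccc12`: in a functional assay on MCF7 cells (Homo sapiens) for antiproliferative activity, read by MTT assay, with a stated time of 48 h (a lower number here means a stronger inhibitor, a higher number a weaker inhibitor), compound 1 returns only the limit > 50000 nM.
Compound 2 `Cc1ccc(-n2nncc2CN2C(=O)C3(C(C#N)=C(N)Oc4c3c3nc5ccccc5nc3c3ccccc43)c3ccccc32)c(C)c1`: in this assay compound 2 likewise returns only the limit > 50000 nM.
Compound 3 `N#CC1=C(N)Oc2c(N)cc3nc4ccccc4nc3c2C12C(=O)N(Cc1cnnn1-c1ccccc1Cl)c1ccccc12`: in this assay compound 3 gives 34400 nM.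

Compound 3 thus stands as the only one of the three with a number; the other two values are limits of this assay. Among the measured compounds shown here, the one step between measured compounds that differ in a single place, from compound 1 to compound 2, swaps 2,4-dimethylphenyl for 4-fluorophenyl on an aromatic nitrogen, and its size cannot be read a step that the two limits leave unreadable from compound 1 to compound 2 because of the limit of > 50000 nM in this assay, at which 2 of the 3 values shown sit.

Compound 4 `COc1ccc(OC)c(-n2nncc2CN2C(=O)C3(C(C#N)=C(N)Oc4c(N)cc5nc6ccccc6nc5c43)c3ccccc32)c1` differs from compound 3 by 2,5-dimethoxyphenyl in place of 2-chlorophenyl on an aromatic nitrogen. For the measured compounds named here, no measured step touches this kind of change, and the single step available is unreadable, so nothing in the set points to a direction. In this assay compound 4 is therefore expected to sit near compound 3, with the step from compound 3 to compound 4 estimated as a 1.2-fold higher number from compound 3 to compound 4 (0.07 log units; within the scatter). Compound 4 is estimated at 40000 nM, in a range from 15000 nM to 100000 nM, and a result reported only as a limit would not be surprising.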

Compound 4, half-maximal inhibitory concentration: 28100 nM
Compound 4: the middle estimate sits 1.4-fold (0.15 log units) above what was measured; the range from low to high includes it.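

Among the compounds shown here, at this position, on the aromatic nitrogen of the five-membered ring, the exchange of 2-chlorophenyl for 2,5-dimethoxyphenyl gives a 1.2-fold lower number from compound 3 to compound 4 (0.09 log units; within the scatter) in this assay, the first step here that can be read. The entering group has more heavy atoms and brings two hydrogen-bond acceptors, yet for this pair the read-out does not move beyond the scatter. This is one pair only, so it shows no general tolerance at this position.

For the compounds shown here, whether the group on this nitrogen matters on the core of compound 1 stays open, because the only step there cannot be read: the limit of > 50000 nM in this assay, at which 2 of the 4 values shown sit. Also open, from the compounds shown here alone, is whether an amine or a carboxylic acid on this phenyl ring, or a plain alkyl chain in its place, would shift the number beyond the scatter.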